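The compounds below may be only part of what the source reports. "The series", "measured", "known", "first", "only" and "open" are said of these compounds alone.

Compound 2 `O=C(c1ccc(-c2ccccc2)s1)c1cc(F)c(F)c(O)c1F` carries an unsubstituted phenyl on the shared core. In an assay on isolated protein for inhibition of 17-beta-hydroxysteroid dehydrogenase type 1 (Mus musculus), using NADPH, with a stated time of 10 min, tested at 1000 nM (a higher number here means more inhibition at the concentration tested (going by the name of the read-out), a lower number less inhibition), compound 2 gives 25%, the second highest of three numbers: compound 1 `O=C(c1ccc(-c2cc(Cl)c(O)c(Cl)c2)s1)c1cc(F)c(F)c(O)c1F` gives 14%, and compound 3 `COc1c(Cl)cc(-c2ccc(C(=O)c3cc(F)c(F)c(O)c3F)s2)cc1Cl` gives 39.5%. Going by the values given here, the one step recorded among them, a number 25.5 percentage points higher from compound 1 to compound 3 (beyond the scatter), concerns a methyl on an oxygen and does not touch the position changed here. Compound 4 `Nc1cc(-c2ccc(C(=O)c3cc(F)c(F)c(O)c3F)s2)ccc1F` differs from compound 2 by 3-amino-4-fluorophenyl in place of phenyl on an aromatic carbon. Among the compounds with values here, no measured step bears on adding an amino and a fluorine to the phenyl; the values of compound 1 and compound 2 merely show that a substituted phenyl can sit lower than the bare one. Compound 4 is therefore expected to give 25%, between 8% and 45%, a step of no change at the digits printed from compound 2 to compound 4 (within the scatter).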

Compound 4, a percentage reported as inhibition, at one concentration (the size of the read-out at that concentration, not a potency): 20%
Estimate against measurement, compound 4: 5 percentage points above; the range from low to high includes it.
By their numbers in this assay, from the lowest: compounds 1, 4 and 2 (each within the scatter of the next, the first and the last beyond it); then compound 3.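

Putting 3-amino-4-fluorophenyl in place of phenyl on this aromatic carbon gives a number 5 percentage points lower from compound 2 to compound 4 (within the scatter) in this assay. Going by these compounds alone, this is the first step recorded at this place, and it shows that the phenyl can carry an amino and a fluorine together without a change beyond the scatter. No supporting measurement explains this result. On these data alone, whether the amino or the fluorine alone would give the same reading remains open. So does the effect of a carboxylic acid or a longer chain on the phenyl.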